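The source may hold more compounds than are shown below. What is called first, only, known or untested is meant among the compounds shown, and "the series" means these compounds.

Working notes on the series. The shared core is seen in compound 1 `COc1cc(/C=C/C(=O)OCCc2cccc(C)c2)cc(OC)c1O`, which in an assay on PMNL cells for inhibition of Polyunsaturated fatty acid 5-lipoxygenase (Homo sapiens), read by HPLC, with stated times of 5 min and 15 min (on this read-out lower numbers stand for stronger inhibition and higher numbers for weaker inhibition), gives 200 nM. Among the compounds with values here, compound 2 `COc1cc(/C=C/C(=O)OCCc2ccccc2C)cc(OC)c1O` gives 240 nM in this assay and stands highest of the two numbers measured so far, its nearest neighbour being compound 1; the step of a 1.2-fold higher number from compound 1 to compound 2 (0.08 log units; within the scatter) separates them and does not leave the scatter. Compound 3 `COc1cc(/C=C/C(=O)OCCCc2ccccc2)cc(OC)c1O` has not been measured in this assay. Its change from compound 2 is benzyl in place of 2-methylphenyl on a saturated chain carbon, two bonds along the chain from an oxygen next to a carbonyl group. Within the data shown here, the only measured step that bears on this change is a 1.2-fold higher number from compound 1 to compound 2 (0.08 log units; within the scatter), an exchange of 3-methylphenyl for 2-methylphenyl at the same place, which stayed within the scatter. No measured step covers the exchange of a methyl-bearing ring for benzyl at this place, so the direction of that part of the change is not shown by the data. Compound 3 is therefore expected to stay close to its neighbour, with an expected step of a 1.0-fold higher number from compound 2 to compound 3 (0.02 log units; within the scatter), not beyond the scatter. The estimate for compound 3 in this assay is 250 nM, with a range from 120 nM to 520 nM.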

Compound 3, half-maximal inhibitory concentration: 340 nM
Compound 3: middle estimate off by 1.4-fold (0.13 log units), on the low side; the range from low to high includes it.
By their numbers in this assay, from the lowest: compounds 1, 2 and 3 (each within the scatter of the next).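

In this assay, the exchange of benzyl for 2-methylphenyl on a saturated chain carbon, two bonds along the chain from an oxygen next to a carbonyl group, gives a 1.4-fold higher number from compound 2 to compound 3 (0.15 log units; within the scatter) and so does not leave the scatter. The exchange of benzyl for 3-methylphenyl at the same place gives a 1.7-fold higher number from compound 1 to compound 3 (0.23 log units; within the scatter), which is also printed as within the scatter, so the series now shows more than a shift of the methyl between two ring positions: a different seven-carbon group with one aromatic ring, and the same counts of donors, acceptors and charge, is also accommodated at this place without a step beyond the scatter. No order can be drawn among the three compounds, and no measurement to hand offers an explanation for these steps.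

The compounds shown leave open whether a larger departure at this place, such as a longer chain or an amine or carboxylic acid on the aromatic ring, would give a step beyond the scatter. They also leave open what an amide in place of the ester, or changes to the two methoxy groups and the hydroxyl of the shared core, would do in this assay.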